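The source may hold more compounds than are shown below. What is called first, only, known or untested is meant among the compounds shown, and "the series" means these compounds.

Two compounds share one core. Compound 1 `C=CCOC(=O)C1=C(C)NC(C)=C(C(=O)OC)C1c1cccc([N+](=O)[O-])c1` gives in a functional assay on HEK293 cells for antagonist activity at Voltage-dependent L-type calcium channel subunit alpha-1C (Oryctolagus cuniculus), read by FLIPR (a higher number here means a weaker inhibitor, a lower number a stronger inhibitor), a value of 15 nM. Compound 2 `COC(=O)C1=C(C)NC(C)=C(C(=O)OCC(C)[N+](=O)[O-])C1c1cccc([N+](=O)[O-])c1` gives in this assay a value of 108 nM, the higher of the two numbers, and the step of a 7.2-fold higher number from compound 1 to compound 2 (0.86 log units; beyond the scatter) lies beyond the scatter. Compound 3 `COC(=O)C1=C(C)NC(C)=C(C(=O)OCc2ccccc2)C1c1cccc([N+](=O)[O-])c1` differs from compound 2 in one place: phenyl in place of 1-nitroethyl on a saturated chain carbon bound to an oxygen next to a carbonyl group. For the measured compounds named here, no measured step swaps these two groups directly; the only step touching the same position is a 7.2-fold higher number from compound 1 to compound 2 (0.86 log units; beyond the scatter), where the 1-nitroethyl group came in and the number rose. Its departure in compound 3 may take back part of that rise, although what enters is phenyl rather than vinyl, so the size is uncertain. Compound 3 is therefore expected to show a lower number, a step of about a 3.1-fold lower number from compound 2 to compound 3 (0.49 log units; beyond the scatter). The estimate for compound 3 is 35 nM, with a range from 8 nM to 150 nM.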

Compound 3, half-maximal inhibitory concentration: 25 nM
Compound 3: the middle estimate sits 1.4-fold (0.15 log units) above what was measured; the range from low to high includes it.
By their numbers in this assay, from the lowest: compounds 1 and 3 (each within the scatter of the next); then compound 2.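

In this assay, phenyl in place of 1-nitroethyl on the saturated chain carbon gives a 4.3-fold lower number from compound 2 to compound 3 (0.64 log units; beyond the scatter), so the rise seen with 1-nitroethyl does not remain once phenyl stands there. Phenyl in place of vinyl at the same carbon gives a 1.7-fold higher number from compound 1 to compound 3 (0.22 log units; within the scatter), which shows that this position can carry an aromatic ring or vinyl with no change that can be told from scatter, and that among these three groups only 1-nitroethyl stands apart. No measurement here accounts for that difference.

The compounds shown leave open whether the nitro group or the carbon chain of 1-nitroethyl goes with the higher number, a question that a plain ethyl group could help to settle. Also open, as far as these compounds go, is how cyclohexyl, an amine-bearing chain or a carboxylic acid would fare at this carbon.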